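Ring Size on the Alkyne: Cyclopropyl to Cyclohexyl

The source may report more compounds than this note shows. Statements on the series, on what has been measured and on what is new or still open speak of the compounds shown alone.

Of the compounds shown here, three sharing one core have been tested in a functional assay on 1321-N1 cells for agonist activity at Free fatty acid receptor 1 (Homo sapiens), read by calcium flux, with a stated time of 0.4 s; on this read-out higher numbers stand for an effect only at larger amounts of compound and lower numbers for an effect already at smaller amounts. Compound 1 `O=C(O)CCc1ccc(C#CC2CCCC2)cc1` carries a cyclopentyl on the triple-bonded carbon and gives 490 nM in this assay. Compound 3 `O=C(O)CCc1ccc(C#CC2CC2)cc1` carries a cyclopropyl in the same place and gives 5010 nM. Compound 2 `O=C(O)CCc1ccc(C#CC2(O)CCCCC2)cc1` returns only a limit, < 100000 nM, so no number is available for it.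

Among the two actual numbers, compound 3 stands at the higher one; the nearest is compound 1, whose number is lower, a difference of a 10-fold higher number from compound 1 to compound 3 (1.01 log units; beyond the scatter).

Compound 4 `O=C(O)CCc1ccc(C#CC2CCCCC2)cc1` differs from compound 3 in one place: cyclohexyl in place of cyclopropyl on a triple-bonded carbon. Among the measured compounds shown here, the only measured step that bears on this change is the move from cyclopentyl to cyclopropyl, which raised the number by a 10-fold higher number from compound 1 to compound 3 (1.01 log units; beyond the scatter), a large shift. Going the other way, from the three-membered ring to a six-membered one, the expectation is therefore a downward step, roughly as large as that one, landing near where compound 1 sits or somewhat beyond it. Compound 4 is expected to give about 400 nM in this assay, within a range of 130 nM to 1300 nM, which corresponds to an estimated step of a 13-fold lower number from compound 3 to compound 4 (1.10 log units; beyond the scatter).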

Compound 4, half-maximal effective concentration: 513 nM
The estimate for compound 4 lay 1.3-fold (0.11 log units) below the measured number; measured number inside the range.
By their numbers in this assay, from the lowest: compounds 1 and 4 (each within the scatter of the next); then compound 3.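

In this assay, putting cyclohexyl in place of cyclopropyl on the triple-bonded carbon gives a 9.8-fold lower number from compound 3 to compound 4 (0.99 log units; beyond the scatter), so a second larger ring, and not only cyclopentyl, stands clearly apart from the three-membered ring. Exchanging cyclopentyl for cyclohexyl gives a 1.0-fold higher number from compound 1 to compound 4 (0.02 log units; within the scatter), so these two rings cannot be told apart at this position, and adding ring size beyond cyclopentyl brings no readable change among the compounds shown. The step from compound 2 to compound 4, with hydrogen in place of hydroxy on a saturated ring carbon, cannot be read, since compound 2 gives only a limit: the limit of < 100000 nM in this assay, at which 1 of the 4 values shown sits.

Still open, as far as these compounds go, is where along the ring sizes the large change sets in, which a cyclobutyl could help to place, and whether the flat stretch continues to a cycloheptyl or holds for an open chain such as n-pentyl on the same carbon. Also open, from the compounds shown here alone, is how an amine or a methoxy group in place of the hydroxy on the saturated ring carbon would compare with the hydrogen of compound 4.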